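A few compounds are considered here, and "the series" means these few. Any claim that something is new, unique, unknown or untested is made for them only; others in the source may bear on it.

Measured so far:
compound 1 `CCC(=O)Nc1cccc(S(=O)(=O)Oc2ccccc2C(C)C)c1` — 12000 nM
compound 2 `CCCCCC(=O)Nc1cccc(S(=O)(=O)Oc2ccccc2C(C)C)c1` — 11000 nM
compound 3 `CC(C)C(=O)Nc1cccc(S(=O)(=O)Oc2ccccc2C(C)C)c1` — 16000 nM

In a functional assay on HT-1080 cells (Homo sapiens) for antiproliferative activity, read by sulforhodamine B assay, with a stated time of 48 h (on this read-out lower numbers stand for stronger inhibition and higher numbers for weaker inhibition), compound 2 gives the lowest of the three numbers, yet its neighbours sit close: a 1.1-fold lower number from compound 1 to compound 2 (0.04 log units; within the scatter) and a 1.5-fold higher number from compound 2 to compound 3 (0.16 log units; within the scatter) both fall within the scatter, as does a 1.3-fold higher number from compound 1 to compound 3 (0.12 log units; within the scatter). Compound 4 `CC(C)c1ccccc1OS(=O)(=O)c1cccc(NC(=O)CCl)c1` is reached from compound 2 by chloro in place of butyl on a saturated chain carbon bound to a carbonyl carbon. For the measured compounds named here, no measured step exchanges a chain for a chloro, so the three steps bear only indirectly: every change of the acyl chain left this assay essentially unmoved. On that basis compound 4 is expected to show no step beyond the scatter, a 1.2-fold lower number from compound 2 to compound 4 (0.09 log units; within the scatter), with a wide band owing to the unfamiliar group. The estimate for compound 4 is 9000 nM (range 2500 nM to 30000 nM).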

Compound 4, half-maximal inhibitory concentration: 780 nM
The estimate for compound 4 lay 12-fold (1.06 log units) above the measured number; the measured number lies below the stated range.
By their numbers in this assay, from the lowest: compound 4; then compounds 2, 1 and 3 (each within the scatter of the next).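

In this assay, the acyl position proved far from indifferent. Exchanges among the alkyl chains had stayed within the scatter, whereas the chloromethyl group on the carbonyl carbon gives a 14-fold lower number from compound 2 to compound 4 (1.15 log units; beyond the scatter), as well as a 15-fold lower number from compound 1 to compound 4 (1.19 log units; beyond the scatter) and a 21-fold lower number from compound 3 to compound 4 (1.31 log units; beyond the scatter). No evidence at hand speaks to what lies behind this shift.

Going by these compounds, whether the shift depends on chlorine itself remains open. A fluoromethyl or bromomethyl group on the carbonyl carbon would bear on that, as would a plain methyl group or a dichloromethyl group.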